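Notes on the step from tert-butyl to a phenyl-bearing group

The source may hold more compounds than are shown below. What is called first, only, known or untested is meant among the compounds shown, and "the series" means these compounds.

Values in a functional assay for inhibition, with Rattus norvegicus as the target (on this read-out higher numbers stand for weaker inhibition and lower numbers for stronger inhibition), for the measured compounds:
- compound 1 `C[C@@H](/N=c1\c(O)c(O)\c1=N/c1ccc(C#N)cc1)C(C)(C)C` gives 370 nM; 24300 nM (2 entries)
- compound 2 `CC(C)(C)/N=c1\c(O)c(O)\c1=N/c1ccc(C#N)cc1` gives 560 nM
- compound 3 `CC(C)C(C)/N=c1\c(O)c(O)\c1=N/c1ccc(C#N)cc1` gives 1900 nM

Of the two compounds with a single number, compound 2 stands lower, and compound 3 is its nearest neighbour. Compound 1 offers no single number: its entries the several entries of compound 1 in this assay, 370 nM; 24300 nM (2 entries) lie far apart, so it gives no firm guide here.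

The unmeasured compound 4 `CC(C)(/N=c1\c(O)c(O)\c1=N/c1ccc(C#N)cc1)c1ccccc1` differs from compound 2 at one place: phenyl in place of methyl on a saturated chain carbon bound to a double-bonded nitrogen and two saturated chain carbons.

Going by the values given here, only one clean measured step bears on this change, and it is modest and beyond the scatter: a 3.4-fold higher number from compound 2 to compound 3 (0.53 log units; beyond the scatter). Among the compounds with values here, that step swaps one saturated group for another, and no aromatic group has yet been measured in this place, so it is a loose guide. A modest rise of similar size is expected in this assay rather than a large shift in either direction.

The expected step is a 2.3-fold higher number from compound 2 to compound 4 (0.37 log units; beyond the scatter) and no larger change is assumed.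

For compound 4 the estimated value is 1300 nM, with an expected range from 350 nM to 6000 nM as the outcome.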

Compound 4, half-maximal inhibitory concentration: > 30000 nM
Compound 4: a limit, no number; the forecaster's own chance of this, stated with the estimate: 5%; middle value at least 23-fold (1.36 log units) away from the limit.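

In this assay, compound 4 gives > 30000 nM, which is a limit of the assay and not a number. Read against that limit, the change is an at least 53-fold higher number from compound 2 to compound 4 (1.72 log units; beyond the scatter), a step of a different size from the swap between saturated groups, a 3.4-fold higher number from compound 2 to compound 3 (0.53 log units; beyond the scatter). The position therefore responds far more strongly to phenyl in place of methyl on a saturated chain carbon bound to a double-bonded nitrogen and two saturated chain carbons than the two compounds with saturated groups alone could show, although this rests on a single pair.

Going by these compounds, it remains open whether the large step follows from the aromatic ring as such or simply from the larger group, and a cyclohexyl group in the same place would separate these two readings. Compound 1 adds no firm reading on how far saturated branching is accepted here: the several entries of compound 1 in this assay, 370 nM; 24300 nM (2 entries)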